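A few compounds are considered here, and "the series" means these few. Any claim that something is new, unique, unknown or untested is made for them only; others in the source may bear on it.

Measured so far:
compound 1 `CC1CCN(c2nc(C(F)(F)F)ccc2CNC(=O)Nc2cccc3c(=O)[nH]ccc23)CC1` — 35.3 nM
compound 2 `CC1CCN(c2nc(C(F)(F)F)ccc2CNC(=O)Nc2cccc3cc[nH]c(=O)c23)CC1` — 239 nM
compound 3 `CC1CCN(c2nc(C(F)(F)F)ccc2CNC(=O)Nc2ccc3[nH]c(=O)ccc3c2)CC1` — 39.9 nM

All three share one core and differ only in the group on the amide-type nitrogen of the urea. In an assay on CHO cells for displacement of a labelled ligand from transient receptor potential cation channel subfamily V member 1 (Homo sapiens) (a higher number here means a weaker inhibitor, a lower number a stronger inhibitor), compound 3 gives the second highest of the three numbers; its nearest neighbour is compound 1, a 1.1-fold higher number from compound 1 to compound 3 (0.05 log units; within the scatter), and its furthest is compound 2, a 6.0-fold lower number from compound 2 to compound 3 (0.78 log units; beyond the scatter).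

Compound 4 `CC1CCN(c2nc(C(F)(F)F)ccc2CNC(=O)Nc2ccc3ccc(=O)[nH]c3c2)CC1` is not yet measured. Against compound 3 the change is a group of 11 heavy atoms (9 carbon, 1 nitrogen, 1 oxygen; one six-membered aromatic ring of carbon only, one six-membered aromatic ring with 1 hetero atom) in place of a group of 11 heavy atoms (9 carbon, 1 nitrogen, 1 oxygen; one six-membered aromatic ring of carbon only, one six-membered aromatic ring with 1 hetero atom), on an amide-type nitrogen; the two have the same atoms, joined differently.

The three measured steps all bear on this change, since each is a swap of one such group for another on the same nitrogen: a 6.8-fold higher number from compound 1 to compound 2 (0.83 log units; beyond the scatter), a 1.1-fold higher number from compound 1 to compound 3 (0.05 log units; within the scatter), a 6.0-fold lower number from compound 2 to compound 3 (0.78 log units; beyond the scatter). Such swaps have therefore given anything from a step within the scatter to a modest one, in either direction. For compound 4 a number near the two lower values is expected, with a range wide enough to reach the weaker case.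

In this assay compound 4 is expected at 65 nM, with a range from 20 nM to 260 nM. That estimate means a step of a 1.6-fold higher number from compound 3 to compound 4 (0.21 log units; within the scatter).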

Compound 4, inhibition constant: 2.95 nM
Compound 4: middle estimate off by 22-fold (1.34 log units), on the high side, and the stated range ends above it.
By their numbers in this assay, from the lowest: compound 4; then compounds 1 and 3 (each within the scatter of the next); then compound 2.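

In this assay the step of a 14-fold lower number from compound 3 to compound 4 (1.13 log units; beyond the scatter) is larger than any earlier swap on this nitrogen, so rejoining the same atoms, with no change in the counted rings, donors or acceptors, can move the number by a large amount. The steps of a 12-fold lower number from compound 1 to compound 4 (1.08 log units; beyond the scatter) and an 81-fold lower number from compound 2 to compound 4 (1.91 log units; beyond the scatter) are also large, which sets compound 4 apart from all three earlier isomers and shows that this position is more sensitive to the arrangement of the group than those isomers indicated. No measurement here bears on the reason for the difference.

On these data alone, whether the low number of compound 4 persists with a methyl group in place of the hydrogen on the ring nitrogen of the entering group remains open. As far as these compounds go, the effect of a chlorine or a methoxy group on that group is also open.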